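Ethoxy variant of the oxazinone propanoic acid series

The source may report more compounds than this note shows. Statements on the series, on what has been measured and on what is new or still open speak of the compounds shown alone.

Measured compounds:
compound 1 `C[C@@H](Oc1cc2oc(=O)n(CCC(=O)O)c2cc1Cl)c1cccnn1`: 1.26 nM
compound 2 `O=C(O)CCn1c(=O)oc2cc(OCc3ccccn3)c(Cl)cc21`: 3.16 nM
compound 3 `O=C(O)CCn1c(=O)oc2cc(OCC3CC3)c(Cl)cc21`: 10 nM

All three numbers come from an assay for inhibition of kynurenine 3-monooxygenase (Homo sapiens), read by mass spectrometry, with a stated time of 1 h; a lower number here means a stronger inhibitor, a higher number a weaker inhibitor. Compound 3 gives the highest number of the three: in this assay compound 3 stands at 10 nM, with the step of a 3.2-fold higher number from compound 2 to compound 3 (0.50 log units; beyond the scatter) to its nearest neighbour and the step of a 7.9-fold higher number from compound 1 to compound 3 (0.90 log units; beyond the scatter) to the furthest. The remaining pair shows a 2.5-fold higher number from compound 1 to compound 2 (0.40 log units; beyond the scatter).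

Compound 4 `CCOc1cc2oc(=O)n(CCC(=O)O)c2cc1Cl` has not been measured. It differs from compound 3 in one place: methyl in place of cyclopropyl on a saturated chain carbon bound to an oxygen on an aromatic ring. The change sits on the same saturated chain carbon bound to the aromatic oxygen that was varied in every measured step. Those steps all moved the number upward as the group on that carbon was replaced by a smaller one, and the step bearing most directly on compound 4 is the replacement of pyridin-2-yl by cyclopropyl, a 3.2-fold higher number from compound 2 to compound 3 (0.50 log units; beyond the scatter). Methyl is smaller again, so a further modest rise beyond the scatter is expected, not a fall. The step from compound 3 to compound 4 is estimated at a 2.5-fold higher number from compound 3 to compound 4 (0.40 log units; beyond the scatter). Compound 4 is therefore expected to give 25 nM in this assay, within a range of 8 nM to 80 nM.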

Compound 4, half-maximal inhibitory concentration: 5.01 nM
Compound 4: the middle estimate sits 5.0-fold (0.70 log units) above what was measured, outside the stated range (below it).
By their numbers in this assay, from the lowest: compound 1; then compounds 2, 4 and 3 (each within the scatter of the next, the first and the last beyond it).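

In this assay, the smallest group yet on the saturated chain carbon bound to the aromatic oxygen carries no penalty: methyl in place of cyclopropyl gives a 2.0-fold lower number from compound 3 to compound 4 (0.30 log units; within the scatter), and methyl in place of pyridin-2-yl gives a 1.6-fold higher number from compound 2 to compound 4 (0.20 log units; within the scatter), so compound 4 lies within the scatter of both compound 2 and compound 3, even though those two lie beyond the scatter of each other. Among these compounds, the upward drift with shrinking group that the first three compounds suggested therefore does not extend to methyl, with compound 4 going against it, and only the step to compound 1 remains clearly resolved, a 4.0-fold higher number from compound 1 to compound 4 (0.60 log units; beyond the scatter), where the change is hydrogen in place of pyridazin-3-yl on a saturated chain carbon. No measurement at hand accounts for this result.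

The compounds shown leave open whether the lower number of compound 1 goes with its pyridazin-3-yl ring or with its additional saturated chain carbon, since the two occur together. Also open, on these data alone, is whether a longer chain such as butyl, or an amine or a hydroxyl on that carbon, would keep the number close to that of compound 4.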